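The compounds below may be only part of what the source reports. "The series", "measured", "known", "first", "only" and "open" are said of these compounds alone.

In an ADME assay on brain (Rattus norvegicus) for protein binding (a lower number here means a smaller unbound share, a higher number a larger unbound share of the compound), compound 1 `Cc1ncccc1N1C[C@]2(CC[C@@H](CNc3cnn(-c4ccccc4F)c3)CC2)OC1=O` has the entry "not determined" (no result reported), so it offers no number for comparison. Compound 2 `O=C1O[C@]2(CC[C@H](CNc3cnn(-c4ccccc4F)c3)CC2)CN1c1cncnc1` gives 0.044 and compound 3 `O=C1O[C@]2(CC[C@H](CNc3cnn(-c4ccccc4F)c3)CC2)CN1c1cccnn1` gives 0.031. Within the data shown here, these two values lie within the scatter of each other, so compound 3 stands level with the only other number available. Compound 4 `O=C1O[C@]2(CC[C@H](CNc3cnn(-c4ccccc4F)c3)CC2)CN1c1cccnc1` carries pyridin-3-yl in place of pyridazin-3-yl on an amide-type nitrogen in a ring. Among the measured compounds shown here, the only measured swap at this place is a 1.4-fold lower number from compound 2 to compound 3 (0.15 log units; within the scatter), so no change beyond the scatter is expected here. The expected step is a 1.1-fold lower number from compound 3 to compound 4 (0.06 log units; within the scatter). For compound 4, the estimated value is 0.027, with an expected range from 0.014 to 0.052.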

Compound 4, unbound fraction: 0.025
For compound 4 the middle estimate is 1.1-fold (0.03 log units) above the measured one, and the stated range covers the measured number.
By their numbers in this assay, from the lowest: compounds 4, 3 and 2 (each within the scatter of the next).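

Replacing pyridazin-3-yl with pyridin-3-yl leaves one fewer nitrogen in the ring, yet the change stays within the scatter (a 1.2-fold lower number from compound 3 to compound 4 (0.09 log units; within the scatter)), as does replacing pyrimidin-5-yl with pyridin-3-yl (a 1.8-fold lower number from compound 2 to compound 4 (0.25 log units; within the scatter)). At this place on the amide-type nitrogen, these three six-membered aromatic rings therefore cannot be told apart in this assay. No outside data bear on this result.

Still open, on these data alone, is whether a plain phenyl ring, with no ring nitrogen, or a non-aromatic morpholine ring at this place would shift the number beyond the scatter.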